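Adding 4-methoxyphenyl to compound 2

The source may hold more compounds than are shown below. What is called first, only, known or untested is meant among the compounds shown, and "the series" means these compounds.

Measured in a functional assay on HCT-116 cells (Homo sapiens) for inhibition, read by MTT assay, with a stated time of 72 h, in the presence of a further agent that is not named here; on this read-out higher numbers stand for an effect only at larger amounts of compound and lower numbers for an effect already at smaller amounts:
compound 1 `CN(C)c1nc(NNC(=O)Nc2cc(Cl)nc(Cl)c2)nc2c1ccn2C`: 41500 nM
compound 2 `O=C(Nc1cc(Cl)nc(Cl)c1)Nc1cc2ccccn2n1`: 5130 nM

Within the data shown here, only two compounds have numbers so far. Compound 2 has the lower number of the pair at 5130 nM, while compound 1 stands at 41500 nM, and this gap lies beyond the usual scatter of repeated measurements. A lower number here means an effect at smaller amounts of compound.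

Compound 3 `COc1ccc(-c2ccc3cc(NC(=O)Nc4cc(Cl)nc(Cl)c4)nn3c2)cc1` changes compound 2 in one place, with 4-methoxyphenyl in place of hydrogen on an aromatic carbon. That carbon belongs to a six-membered aromatic ring with 1 nitrogen, part of a fused or bridged system of two rings. Among the measured compounds shown here, no measured pair shows what a change at this place does in this assay, so the forecast is loose and its only anchor is compound 2 at 5130 nM. The expected move is a moderate one toward a lower number, only a little beyond the scatter: a 2.6-fold lower number from compound 2 to compound 3 (0.41 log units; beyond the scatter) is the estimate. For compound 3 the estimated value is 2000 nM, with an expected range from 400 nM to 10000 nM.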

Compound 3, half-maximal effective concentration: 5350 nM
The estimate for compound 3 lay 2.7-fold (0.43 log units) below the measured number; the range from low to high includes it.
By their numbers in this assay, from the lowest: compounds 2 and 3 (each within the scatter of the next); then compound 1.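

In this assay, putting 4-methoxyphenyl in place of hydrogen on this aromatic carbon gives a 1.0-fold higher number from compound 2 to compound 3 (0.02 log units; within the scatter), so the read-out does not separate the two compounds. Among these compounds, this is the first measured pair at this place, two atoms from the ring nitrogen, and it shows something that compound 1 and compound 2 could not: a whole extra aromatic ring carrying a methoxy group can be attached here without the number leaving the scatter. No supporting measurements accompany this result, so the unchanged number remains without an explanation.

A single pair cannot tell whether this flat result is particular to 4-methoxyphenyl or holds more widely for groups on this carbon. The compounds shown also leave open what a carboxylic acid or an amine would do, whether attached directly to this carbon or standing in place of the methoxy group on the added phenyl ring, and either change could move the number in either direction or not at all.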